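A few compounds are considered here, and "the series" means these few. Any claim that something is new, unique, unknown or untested is made for them only; others in the source may bear on it.

Of the compounds shown here, three have been measured in an assay on isolated protein for inhibition of thyroid hormone receptor beta (Homo sapiens), read by fluorescence, with a stated time of 30 min; a higher number here means a weaker inhibitor, a lower number a stronger inhibitor. Compound 1 `O=C(NCc1cccc(Cl)c1)c1ccc2cn(CCN3CCOC3=O)nc2c1` gives 220 nM, and compound 2 `CCCN(CC1CCOC1)C(=O)c1cc(CC)c2oc(NCc3cccc(Cl)c3)nc2c1` gives 104 nM. Compound 3 `COc1cc(C(=O)N2CCC(O)C(C)C2)cc2nc(NCc3ccnc(Cl)c3)oc12` stands apart: in this assay compound 3 gives 6900 nM, the highest of the three numbers, so it is the weakest inhibitor in this set; the gap to compound 1 and the larger gap to compound 2 both lie beyond the usual scatter of repeated measurements.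

Compound 4 `COc1cc(C(=O)N2CCC(O)C(C)C2)cc2nc(N[C@H](C)c3cccc(Cl)c3)oc12` is the next compound, not yet measured. It differs from compound 3 in one place: 1-(3-chlorophenyl)ethyl in place of (2-chloropyridin-4-yl)methyl on a nitrogen on an aromatic ring. Nothing else in the shared core changes.

Among the compounds with values here, no measured pair differs in exactly this way, so the expectation rests on the wider picture. Compound 1 and compound 2 both carry a chlorophenyl group and both give lower numbers than compound 3. Compound 2 in particular carries its chlorophenyl group on a nitrogen of the same kind as in compound 3. In this assay compound 2 gives 104 nM. Going by these compounds, on that basis compound 4 is expected to give a lower number than compound 3, by a step of about a 4.6-fold lower number from compound 3 to compound 4 (0.66 log units; beyond the scatter), though the extra methyl and the stereocentre are untested here. For compound 4 the estimate in this assay is 1500 nM, with a likely range from 400 nM to 6000 nM.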

Compound 4, half-maximal inhibitory concentration: 48 nM
Compound 4: the middle estimate sits 31-fold (1.49 log units) above what was measured; the measured number lies below the stated range.
By their numbers in this assay, from the lowest: compound 4; then compound 2; then compound 1; then compound 3.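

In this assay, putting 1-(3-chlorophenyl)ethyl in place of (2-chloropyridin-4-yl)methyl on this nitrogen gives a 140-fold lower number from compound 3 to compound 4 (2.16 log units; beyond the scatter), with nothing else in the molecule altered. Within the data shown here, this is the first direct evidence that this one place can carry a large shift by itself, as the earlier compounds offered no pair differing in a single place. The swap is still several differences at once, since a six-membered aromatic ring with one hetero atom gives way to one of carbon only, the group grows from 8 to 9 heavy atoms, and a defined stereocentre enters; no measured evidence here separates these differences or explains the step.

The compounds shown leave open how the opposite form of the stereocentre would compare, and what a longer chain in a 1-(3-chlorophenyl)propyl group or a different ring substituent in a 1-(3-methoxyphenyl)ethyl group would give on this nitrogen. They also leave open whether the same swap would give a step of similar size if the rest of the molecule were changed.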